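The source may hold more compounds than are shown below. What is called first, only, known or untested is meant among the compounds shown, and "the series" means these compounds.

Measured compounds:
- compound 1 `CCC(C)(C)Cc1c[nH]c(CCc2ccc(-n3ccnn3)cc2)n1`: 111 nM
- compound 2 `CCC(C)(C)Cc1c[nH]c(CCc2ccc(-c3cnccn3)cc2)n1`: 107 nM

Among the compounds with values here, in a functional assay on HEK293 cells for agonist activity at Bombesin receptor subtype-3 (Mus musculus), read by luminescence and calcium flux, with a stated time of 10 min (a lower number here means that less compound is needed, a higher number that more compound is needed for the effect), compound 2 gives 107 nM, and compound 1 gives 111 nM, so the two stand together within the scatter; the one measured step, a 1.0-fold lower number from compound 1 to compound 2 (0.02 log units; within the scatter), shows the exchange of one aromatic ring for another at the same aromatic carbon leaves the number essentially unchanged. Compound 3 `CCC(C)(C)Cc1c[nH]c(CCc2ccc(-c3ccccc3C(=O)O)cc2)n1` differs from compound 2 by 2-carboxyphenyl in place of pyrazin-2-yl on an aromatic carbon. Within the data shown here, the only step that bears on this change is the one just described, and it was flat, but the entering group is larger and brings a hydrogen-bond donor that neither earlier group carried, so the single step is weak guidance. The expected change is a 1.9-fold higher number from compound 2 to compound 3 (0.27 log units; within the scatter), a modest rise at most. Compound 3 is therefore estimated at 200 nM, with a range from 60 nM to 700 nM.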

Compound 3, half-maximal effective concentration: 94 nM
The estimate for compound 3 lay 2.1-fold (0.33 log units) above the measured number, and the stated range covers the measured number.
By their numbers in this assay, from the lowest: compounds 3, 2 and 1 (each within the scatter of the next).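

In this assay the exchange of pyrazin-2-yl for 2-carboxyphenyl on an aromatic carbon para to a large group gives a 1.1-fold lower number from compound 2 to compound 3 (0.06 log units; within the scatter) and the exchange of 1H-1,2,3-triazol-1-yl for the same group gives a 1.2-fold lower number from compound 1 to compound 3 (0.07 log units; within the scatter) on the same reading. Within the data shown here, the position, until now seen only with rings containing nitrogen, thus also takes a larger group with a six-membered aromatic ring of carbon only and a hydrogen-bond donor, and the number stays within the scatter.

The compounds shown leave open whether the carboxylic acid contributes at all, as a plain phenyl ring, a methyl ester or a primary amide in its place would test. Also open, as far as these compounds go, is whether an amine or a longer chain at this carbon would stay level with these three. No measurement given here explains why the three numbers stand together.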